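Changing the Arylamino Ring of Compound 2

The compounds below may be only part of what the source reports. "The series", "measured", "known", "first", "only" and "open" are said of these compounds alone.

Compound 1 `CCCOc1ccc(C(=O)Nc2cccc(Br)n2)cc1` and compound 2 `CCCOc1ccc(C(=O)Nc2cccc(Nc3ccccc3F)n2)cc1` share one core and differ at a single aromatic carbon. In an in vitro assay on HEK-tsA201 cells for antagonist activity at Neuronal acetylcholine receptor; alpha4/beta2 (Homo sapiens), read by fluorescence and calcium flux (on this read-out lower numbers stand for stronger inhibition and higher numbers for weaker inhibition), compound 1 gives 80700 nM. For compound 2 this assay reports only a limit, > 100000 nM. The step of an at least 1.2-fold higher number from compound 1 to compound 2 (0.09 log units; that floor lies within the scatter) has a floor that lies within the scatter, and its true size is not known; this is the situation described by the limit of > 100000 nM in this assay, at which 1 of the 2 values shown sits.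

Compound 3 `CCCOc1ccc(C(=O)Nc2cccc(Nc3ccc(OC)cc3)n2)cc1` keeps everything of compound 2 except the change (4-methoxyphenyl in place of 2-fluorophenyl on a nitrogen on an aromatic ring). Among the compounds with values here, no measured step concerns an exchange of one aryl ring for another on this nitrogen; the only measured step, from compound 1 to compound 2, replaces bromo by an arylamino group and ends at the limit. Compound 2 sits at the limit in this assay, and no numeric base exists from which a change could be read. Compound 3 is expected to stay near that limit, with the step of a number no higher from compound 2 to compound 3 (the limit leaves the size open) expected to lie within the scatter. The estimate for compound 3 is 100000 nM, with a range from 30000 nM to 300000 nM, and a fair chance that this assay again reports only a limit.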

Compound 3, half-maximal inhibitory concentration: > 100000 nM
Compound 3: only a limit was reported; the forecaster's own chance of this, stated with the estimate: 70%; the middle value sits exactly at the limit.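

In this assay compound 3 gives only a limit, > 100000 nM. The step of an at least 1.2-fold higher number from compound 1 to compound 3 (0.09 log units; that floor lies within the scatter) leaves the true size open, but it shows that a second aryl ring on this nitrogen, here 4-methoxyphenyl, also gives no numeric value when (4-methoxyphenyl)amino stands in place of bromo on the aromatic carbon. The exchange of 2-fluorophenyl for 4-methoxyphenyl cannot be read, and no ranking of the two rings can be given, because both values end at the same limit: the limit of > 100000 nM in this assay, at which 2 of the 3 values shown sit.

The compounds shown leave open how far either arylamino compound lies past that limit, and whether any group at this position can give a numeric value in this assay. Among them, only the bromo compound has a number, so it also remains open whether a small group such as an amine, or an aryl ring carrying a carboxylic acid, would bring the read-out back within the range of this assay.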